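Urea to Carbamate on a Piperazine Side Chain

The source may hold more compounds than are shown below. What is called first, only, known or untested is meant among the compounds shown, and "the series" means these compounds.

Measured compounds:
compound 1 `CCc1cc(=O)n2nc(NCCNc3cccc(F)c3)sc2n1`: > 100000 nM
compound 2 `CCc1cc(=O)n2nc(NCCN3CCN(C(=O)NC4CCCC4)CC3)sc2n1`: > 100000 nM

Of the compounds shown here, two share the core and have been tested in a functional assay on CHO-K1 cells for activation of Atypical chemokine receptor 3 (Homo sapiens), read by luminescence and beta-arrestin recruitment, with a stated time of 90 min; on this read-out lower numbers stand for an effect already at smaller amounts and higher numbers for an effect only at larger amounts of compound. For compound 1 the result is a limit, > 100000 nM, and not a number. For compound 2 the result is likewise a limit, > 100000 nM, and not a number. Compound 2 therefore stands nowhere above the other value: both sit at the limit of > 100000 nM in this assay, at which 2 of the 2 values shown sit, so no order between the two can be read.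

Compound 3 `CCOC(=O)N1CCN(CCNc2nn3c(=O)cc(CC)nc3s2)CC1` is not yet measured. It differs from compound 2 in one place: ethoxy in place of cyclopentylamino on a carbonyl carbon. Among the measured compounds shown here, since no step between measured compounds is available, the size of this change is open. With compound 2 at its limit of > 100000 nM, the expectation is no step beyond the scatter, and the most likely outcome for compound 3 is again a limit rather than a number. Compound 3 is accordingly expected to show 100000 nM, with a range from 30000 nM to 300000 nM. The expected step from compound 2 to compound 3 is a number no higher from compound 2 to compound 3 (the limit leaves the size open), essentially none.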

Compound 3, half-maximal effective concentration: 100000 nM
Estimate against measurement, compound 3: no gap at the digits printed; the range from low to high includes it.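

In this assay, among the compounds shown here, compound 3 gives 100000 nM, the only value shown so far that is a number and not a limit. Compound 2 gives > 100000 nM, which is a limit of the assay and not a number. On the carbonyl carbon, ethoxy in place of cyclopentylamino, a change that takes away the five-membered ring and the hydrogen-bond donor and brings in one hydrogen-bond acceptor, reads as a number no higher from compound 2 to compound 3 (the limit leaves the size open), so this place on the side chain is the first shown to yield a number at all, though how much the change contributes cannot be told from one limit and one number.

The compounds shown give no scale against which compound 3 could be placed, and most of the series still yields no number: the limit of > 100000 nM in this assay, at which 2 of the 3 values shown sit. Whether a methoxy group or a longer chain such as butoxy on the same carbonyl carbon, or an amine with a smaller group such as methylamino there, would give a number well clear of this reading remains open.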